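The source may hold more compounds than are shown below. What is called first, only, known or untested is meant among the compounds shown, and "the series" means these compounds.

Two measured compounds share one core and differ only in the group on an amide-type nitrogen. Compound 1 `O=C(Nc1c(F)cccc1F)c1cn(Cc2c(F)cccc2F)c2ccc(=O)[nH]c2c1=O` carries a 2,6-difluorophenyl there. In an in vitro assay on Sf21 cells for inhibition of high affinity 3',5'-cyclic-AMP phosphodiesterase 7A (Homo sapiens), read by scintillation proximity assay, with a stated time of 30 min (a lower number here means a stronger inhibitor, a higher number a weaker inhibitor), compound 1 gives only a limit, > 1000 nM. Compound 2 `O=C(O)Cc1ccc(NC(=O)c2cn(Cc3c(F)cccc3F)c3ccc(=O)[nH]c3c2=O)cc1` carries a 4-(carboxymethyl)phenyl instead, and in this assay compound 2 gives 176 nM, the only full number shown, since the other value sits at the limit of > 1000 nM in this assay, at which 1 of the 2 values shown sits. Compound 3 `COc1cc(NC(=O)c2cn(Cc3c(F)cccc3F)c3ccc(=O)[nH]c3c2=O)cc(OC)c1` changes the same position again: 3,5-dimethoxyphenyl in place of 4-(carboxymethyl)phenyl on an amide-type nitrogen. Within the data shown here, one measured step bears on this, an at least 5.6-fold lower number from compound 1 to compound 2 (0.75 log units; beyond the scatter), which came with the arrival of the single hydrogen-bond donor that compound 3 gives up again, while compound 1, also without such a donor, sat at the limit of > 1000 nM in this assay, at which 1 of the 2 values shown sits. A move back toward weaker inhibition is therefore expected, a 4.0-fold higher number from compound 2 to compound 3 (0.60 log units; beyond the scatter), with wide uncertainty because the two methoxy groups do not repeat the pattern of compound 1 at the limit of > 1000 nM in this assay, at which 1 of the 2 values shown sits. Compound 3 is estimated at 700 nM in this assay, within 150 nM to 3000 nM.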

Compound 3, half-maximal inhibitory concentration: 212 nM
For compound 3 the middle estimate is 3.3-fold (0.52 log units) above the measured one; the range from low to high includes it.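

Placing 3,5-dimethoxyphenyl where compound 2 has 4-(carboxymethyl)phenyl gives a 1.2-fold higher number from compound 2 to compound 3 (0.08 log units; within the scatter), so in this assay the hydrogen-bond donor of compound 2 is not required at this position for a number in this range. The other new step, an at least 4.7-fold lower number from compound 1 to compound 3 (0.67 log units; beyond the scatter), shows that a group without that donor can still stand clear of compound 1, so the missing donor alone does not account for the weak result of the 2,6-difluorophenyl compound. Compound 1 remains the only one of the three that gives a limit and not a number: the limit of > 1000 nM in this assay, at which 1 of the 3 values shown sits.

From the compounds shown here alone, what the 4-(carboxymethyl)phenyl and 3,5-dimethoxyphenyl groups share that matters here stays open, as does whether the two fluorines of compound 1 are what sets it apart. An unsubstituted phenyl, or a phenyl carrying an amine, would help separate these possibilities.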